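Piperidinyl for phenyl, carried from amide to ester

The compounds below may be only part of what the source reports. "The series", "measured", "known", "first", "only" and "open" are said of these compounds alone.

Three compounds are measured in a functional assay on cells (Oocyte) for inhibition of Voltage-dependent T-type calcium channel subunit alpha-1H (Homo sapiens), tested at 100 uM; a higher number here means more inhibition at the concentration tested (going by the name of the read-out), a lower number less inhibition. Compound 1 `O=C(CC1c2ccccc2N=C(N2CCCCC2)N1c1ccccc1)NCc1ccccc1` gives 77%, compound 2 `O=C(CC1c2ccccc2N=C(c2ccccc2)N1c1ccccc1)NCc1ccccc1` gives 14.8%, and compound 3 `O=C(CC1c2ccccc2N=C(c2ccccc2)N1c1ccccc1)OCc1ccccc1` gives 14.2%. Between compound 2 and compound 1 the change is piperidin-1-yl in place of phenyl on a carbon with a double bond to nitrogen, and the step it made is a number 62.2 percentage points higher from compound 2 to compound 1 (beyond the scatter). The core of compound 3 differs from that of compound 2 by benzyloxy in place of benzylamino on a carbonyl carbon, a step of a number 0.6 percentage points lower from compound 2 to compound 3 (within the scatter). Compound 4 `O=C(CC1c2ccccc2N=C(N2CCCCC2)N1c1ccccc1)OCc1ccccc1` carries the same kind of change on the core of compound 3: piperidin-1-yl in place of phenyl on a carbon with a double bond to nitrogen; around the place, the ring atom two ring bonds from it bears a (benzyloxycarbonyl)methyl group rather than a (benzylcarbamoyl)methyl group. Within the data shown here, for compound 4 a step of a number 60.8 percentage points higher from compound 3 to compound 4 (beyond the scatter) is expected in this assay, resting on the single earlier step of a number 62.2 percentage points higher from compound 2 to compound 1 (beyond the scatter). The estimate for compound 4 is 75%, expected to fall between 55% and 90%.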

Compound 4, a percentage reported as inhibition, at one concentration (the size of the read-out at that concentration, not a potency): 15.6%
Beside the measured number, compound 4's estimate is 59.4 percentage points above it, and the stated range ends above it.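

In this assay, piperidin-1-yl in place of phenyl gives a number 1.4 percentage points higher from compound 3 to compound 4 (within the scatter), so the large gain seen on the core of compound 2 does not carry over to the core of compound 3: the same change on two cores in this assay, a number 62.2 percentage points higher (beyond the scatter) from compound 2 to compound 1 and a number 1.4 percentage points higher (within the scatter) from compound 3 to compound 4, 60.8 percentage points apart, beyond the scatter of two such steps. Benzyloxy in place of benzylamino, with no step beyond the scatter on the phenyl-bearing core, gives a number 61.4 percentage points lower from compound 1 to compound 4 (beyond the scatter) on the piperidin-1-yl-bearing core, so the two changes do not act independently in these four compounds: the same change on two cores in this assay, a number 0.6 percentage points lower (within the scatter) from compound 2 to compound 3 and a number 61.4 percentage points lower (beyond the scatter) from compound 1 to compound 4, 60.8 percentage points apart, beyond the scatter of two such steps. This shows that the effect of the change depends on the core, but not why it does, and a single tested concentration says nothing about potency.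

On these data alone, whether a morpholin-4-yl or dimethylamino group would follow piperidin-1-yl remains open. So does the behaviour of a methylated amide or a free carboxylic acid in place of the benzylamino group.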